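A few compounds are considered here, and "the series" means these few. Any claim that something is new, unique, unknown or untested is made for them only; others in the source may bear on it.

Compound 1 `CNC(=O)c1cc(C(=O)NC2CC2)cn(Cc2ccc(OC)cc2)c1=O` gives >= 143 ug/mL in a physicochemical assay for solubility; a higher number here means a more soluble compound, a lower number a less soluble compound; this value is a limit of the assay.
Compound 2 `CNC(=O)c1cc(C(=O)NC2CC2)cn(Cc2cccc([C@@H](C)O)c2)c1=O` gives >= 131 ug/mL; this value is also a limit of the assay.
Compound 3 `CNC(=O)c1cc(C(=O)NC2CC2)cn(Cc2nccc3[nH]ccc23)c1=O` gives 73 ug/mL.

Going by the values given here, compound 3 holds the only number in this set; the other two values are limits. The step from compound 1 to compound 2 cannot be read because of the limit of >= 143 ug/mL in this assay, at which 1 of the 3 values shown sits, and the limit of >= 131 ug/mL in this assay, at which 1 of the 3 values shown sits: a step that the two limits leave unreadable from compound 1 to compound 2. Going to compound 3 lowers the number: an at least 1.9-fold lower number from compound 1 to compound 3 (0.29 log units; that floor lies within the scatter) and an at least 1.7-fold lower number from compound 2 to compound 3 (0.25 log units; that floor lies within the scatter), though each floor lies within the scatter.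

Compound 4 `CNC(=O)c1cc(C(=O)NC2CC2)cn(Cc2cccc(C#N)c2)c1=O` has not yet been measured. Relative to compound 3 it carries a group of 8 heavy atoms (7 carbon, 1 nitrogen; one six-membered aromatic ring of carbon only) in place of a group of 9 heavy atoms (7 carbon, 2 nitrogen; one five-membered aromatic ring with 1 hetero atom, one six-membered aromatic ring with 1 hetero atom), on a saturated chain carbon bound to an aromatic nitrogen. The two steps that bear on this change are the ones that brought the bicyclic group in, from compound 1 and from compound 2; compound 4 reverses that kind of change, returning to a six-membered ring of carbon only with a single substituent, as in compound 1 and compound 2. A step upward in this assay is therefore expected, of about the size seen going the other way: a 1.9-fold higher number from compound 3 to compound 4 (0.28 log units; within the scatter). For compound 4 the estimated value is 140 ug/mL, with a range from 70 ug/mL to 260 ug/mL, and a fair chance that only a limit is reported.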

Compound 4, solubility: >= 148 ug/mL
Compound 4: no number, only a limit; the forecaster's own chance of this, stated with the estimate: 45%; at least 1.0-fold (0.02 log units) between middle value and limit.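

In this assay, replacing the two-ring group with 3-cyanophenyl on a saturated chain carbon bound to an aromatic nitrogen gives an at least 2.0-fold higher number from compound 3 to compound 4 (0.30 log units; that floor lies within the scatter), so this step alone does not establish a difference. Going by these compounds alone, what compound 4 adds is a third group with a six-membered ring of carbon only that ends at a limit, here with 0 hydrogen-bond donors in the group, while compound 3, with its two-ring group, remains the only compound of the four that gives a number. The steps from compound 1 and from compound 2 to compound 4 cannot be read, and so the 3-cyanophenyl group cannot be ranked against the 4-methoxyphenyl group or the cyano against the 1-hydroxyethyl, since compound 4 also stands at a limit: the limit of >= 148 ug/mL in this assay, at which 1 of the 4 values shown sits.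

As far as these compounds go, it remains open how far compound 1, compound 2 and compound 4 lie beyond their limits, and whether the groups on their rings differ at all in this measurement. From the compounds shown here alone, it is also open whether a naphthyl group, with two rings of carbon only, would give a number like compound 3 or a limit like compound 4.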